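Methyl in Place of Hydrogen, Tried a Second Time

The source may report more compounds than this note shows. Statements on the series, on what has been measured and on what is new or still open speak of the compounds shown alone.

Compound 1, `Cc1ccccc1NS(=O)(=O)c1cccc(NC(=O)NCCCCl)c1`, was tested in a functional assay on M21 cells (Homo sapiens) for cytotoxicity, read by sulforhodamine B assay, with a stated time of 48 h (a lower number here means a stronger inhibitor, a higher number a weaker inhibitor), where compound 1 gives 60000 nM. Compound 2, `CCc1ccccc1NS(=O)(=O)c1cccc(NC(=O)NCCCCl)c1`, carries one more carbon on its outer ring. In this assay compound 2 reaches only a limit of the assay, > 200000 nM, so no number is known for it. The change from compound 1 to compound 2, (methyl in place of hydrogen on a saturated chain carbon bound to an aromatic carbon), produced an at least 3.3-fold higher number from compound 1 to compound 2 (0.52 log units; beyond the scatter); the number rose rather than fell.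

Compound 3, `CCNC(=O)Nc1ccc(S(=O)(=O)Nc2ccccc2C)cc1`, is built on a different core; the difference between the two cores is not broken down here. In this assay compound 3 also gives only a limit, > 200000 nM, rather than a number. Compound 4, `CCNC(=O)Nc1ccc(S(=O)(=O)Nc2ccccc2CC)cc1`, has not yet been tested. It differs from compound 3 by methyl in place of hydrogen on a saturated chain carbon bound to an aromatic carbon, the same change that separates compound 1 from compound 2, made at the same place.

What can be expected rests on two points. The step of an at least 3.3-fold higher number from compound 1 to compound 2 (0.52 log units; beyond the scatter) shows that this change did not produce a stronger inhibitor, and compound 3 already sits at the limit of > 200000 nM in this assay, at which 2 of the 3 values shown sit. A step from compound 3 to compound 4 of about a step that the limit leaves unreadable from compound 3 to compound 4 is therefore expected, with a limit more likely than a number. Compound 4 is expected to give about 400000 nM in this assay, with a likely range from 150000 nM to 1500000 nM.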

Compound 4, half-maximal inhibitory concentration: 90000 nM
Beside the measured number, compound 4's estimate is 4.4-fold (0.65 log units) above it; the measured number lies below the stated range.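

In this assay methyl in place of hydrogen on a saturated chain carbon bound to an aromatic carbon gave an at least 2.2-fold lower number from compound 3 to compound 4 (0.34 log units; beyond the scatter) and so moved the number the opposite way from the step on the core of compound 1. The 2-methylphenyl to 2-ethylphenyl change therefore did not carry over from one core to the other, which means that its result on one core could not be used to predict its result on the other, and the two steps differ clearly: the same change on two cores in this assay, an at least 3.3-fold higher number (0.52 log units; beyond the scatter) from compound 1 to compound 2 and an at least 2.2-fold lower number (0.34 log units; beyond the scatter) from compound 3 to compound 4, at least 7.4-fold (0.86 log units) apart, beyond the scatter of two such steps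

This does not show why the direction reverses, and it fixes neither step exactly, because compound 2 and compound 3 each give only a limit, so both steps are minimum sizes: the limit of > 200000 nM in this assay, at which 2 of the 4 values shown sit.

The compounds shown leave open whether a longer chain at this place, such as propyl, or a different group there, such as an amine or a carboxylic acid, would follow the trend of either core. Among the compounds shown here, they also leave open which of the differences between the two cores reverses the step, since these cores differ in more than one place and only two pairs are available to compare.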